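Side-chain replacement at the sulfur-bound carbon

This account rests on a few compounds, and the source may have more. Where it says the series, first, only, none or still open, it means among the compounds named here.

Compound 3 `COc1cc(-c2nnc(SCc3ccccc3)n2-c2ccc(N(C)C)cc2)cc(OC)c1OC` stands at a limit of the assay: in a functional assay on HT-29 cells (Homo sapiens) for inhibition, read by MTT assay, with a stated time of 48 h (on this read-out higher numbers stand for weaker inhibition and lower numbers for stronger inhibition), compound 3 gives > 60000 nM, so no number is known for it. Compound 1 `COc1ccc(-n2c(SCc3ccccc3)nnc2-c2cc(OC)c(OC)c(OC)c2)cc1` also gives only a limit in this assay, > 60000 nM. Going by the values given here, compound 2 `COc1ccc(NC(=O)CSc2nnc(-c3cc(OC)c(OC)c(OC)c3)n2-c2ccc(OC)cc2)cc1` gives 45300 nM in this assay, the one numerical value in the set. The change of dimethylamino in place of methoxy on an aromatic carbon yields a step that the two limits leave unreadable from compound 1 to compound 3, because both values stand at the limit of > 60000 nM in this assay, at which 2 of the 3 values shown sit.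

Compound 4 `COc1cc(-c2nnc(SCC(=O)c3ccc4ccccc4c3)n2-c2ccc(N(C)C)cc2)cc(OC)c1OC` differs from compound 3 in one place: (naphthalen-2-yl)carbonyl in place of phenyl on a saturated chain carbon bound to a sulfur. Among the compounds with values here, the only measured step that bears on this is an at least 1.3-fold lower number from compound 1 to compound 2 (0.12 log units; that floor lies within the scatter), where a carbonyl-bearing group likewise replaced phenyl on a saturated chain carbon bound to a sulfur; its floor lies within the scatter, so it points at best to a small shift toward lower numbers. The same kind of shift is therefore expected here, with compound 4 estimated at 40000 nM, in a range from 12000 nM to 90000 nM, which would mean an expected at least 1.5-fold lower number from compound 3 to compound 4 (0.17 log units; that floor lies within the scatter). A result reported only as a limit remains a real possibility for compound 4.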

Compound 4, half-maximal inhibitory concentration: > 60000 nM
Compound 4: a limit, no number (the forecaster's own chance of this, stated with the estimate: 40%); middle value at least 1.5-fold (0.17 log units) from the limit.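

In this assay compound 4 gives > 60000 nM, a limit and not a number. No step can be read from compound 3 to compound 4, because both stand at the same limit: the limit of > 60000 nM in this assay, at which 3 of the 4 values shown sit.

The compounds shown leave open whether (naphthalen-2-yl)carbonyl in place of phenyl on a saturated chain carbon bound to a sulfur changes the read-out at all.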